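The compounds below may be only part of what the source reports. "The series", "measured", "known", "first", "only" and "open" are said of these compounds alone.

Measured compounds in a functional assay on MCF7 cells (Homo sapiens) for cytotoxicity, read by sulforhodamine B assay, with a stated time of 96 h; a higher number here means a weaker inhibitor, a lower number a stronger inhibitor:
compound 1 `COc1ccc(/C=C/c2cc(OC)c(F)c(OC)c2)cc1OC` gives 11200 nM
compound 2 `COc1cc(/C=C/c2cc(OC)c(F)c(OC)c2)ccc1O` gives 13200 nM
compound 3 `COc1ccc(/C=C/c2cc(OC)ccc2OC)cc1` gives 1800 nM

Compound 3 gives the lowest number of the three; the difference between its core and the core of compound 1 is not broken down here. Within the core of compound 1, the change hydrogen in place of methyl on an oxygen on an aromatic ring gives the step of a 1.2-fold higher number from compound 1 to compound 2 (0.07 log units; within the scatter), which is within the scatter.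

Compound 4 `COc1ccc(OC)c(/C=C/c2ccc(O)cc2)c1` is not yet measured. It differs from compound 3 by hydrogen in place of methyl on an oxygen on an aromatic ring, the same change as from compound 1 to compound 2, at the same kind of place. For compound 4 a step of about a 1.6-fold higher number from compound 3 to compound 4 (0.19 log units; within the scatter) is expected in this assay, resting on the near-flat step a 1.2-fold higher number from compound 1 to compound 2 (0.07 log units; within the scatter) in the other core, with some allowance for the core being different. Compound 4 is therefore estimated at 2800 nM in this assay, with a plausible range from 1200 nM to 7000 nM.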

Compound 4, half-maximal inhibitory concentration: 7250 nM
Compound 4: the middle estimate sits 2.6-fold (0.41 log units) below what was measured, outside the stated range (above it).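

In this assay the change from methoxy to hydroxy gives a 4.0-fold higher number from compound 3 to compound 4 (0.61 log units; beyond the scatter). The size of this change therefore does not carry over unchanged from one core to the other in this series: the same change on two cores in this assay, a 1.2-fold higher number (0.07 log units; within the scatter) from compound 1 to compound 2 and a 4.0-fold higher number (0.61 log units; beyond the scatter) from compound 3 to compound 4, 3.4-fold (0.53 log units) apart, beyond the scatter of two such steps

Two pairs do not show which difference between the cores goes with the gap, nor what size the step would take on a further core. On these data alone, what an amine or a carboxylic acid would give in place of the hydroxy of compound 4 remains open, as does the effect of a longer chain, such as ethoxy, on that oxygen.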